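Swapping a Phenyl for an Indole on the Double Bond

A few compounds are considered here, and "the series" means these few. Any claim that something is new, unique, unknown or untested is made for them only; others in the source may bear on it.

- Compound 1 `Cc1ccc(CS(=O)(=O)/C(=C/c2cc(C)cc(C)c2)C(=O)c2ccc(Cl)cc2)cc1`: 10000 nM
- Compound 2 `CCOc1ccc(/C=C(\C(=O)c2ccc(Cl)cc2)S(=O)(=O)Cc2ccc(C)cc2)cc1OC`: 10000 nM

Both values come from a functional assay on DU-145 cells (Homo sapiens) for inhibition, read by trypan blue exclusion, with a stated time of 96 h; on this read-out higher numbers stand for weaker inhibition of growth and lower numbers for stronger inhibition of growth. For the measured compounds named here, only two compounds have been measured so far, and they stand level, with compound 2 at 10000 nM.

Compound 3 `Cc1ccc(CS(=O)(=O)/C(=C/c2c[nH]c3ccccc23)C(=O)c2ccc(Cl)cc2)cc1` differs from compound 2 in one place: 1H-indol-3-yl in place of 4-ethoxy-3-methoxyphenyl on a double-bonded chain carbon bound to a double-bonded chain carbon. In words, 1H-indol-3-yl stands in place of 4-ethoxy-3-methoxyphenyl.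

Going by the values given here, one measured step bears on this place: no change at the digits printed from compound 1 to compound 2 (within the scatter). Exchanging one substituted phenyl group for another there left the value unchanged. Among the compounds with values here, no indolyl group has yet been measured at this carbon, so this single step is thin evidence. No step beyond the scatter is therefore expected in this assay, but the range is kept wide.

The expected change is a 1.4-fold lower number from compound 2 to compound 3 (0.15 log units; within the scatter).

For compound 3 the estimate is 7000 nM, with an expected range from 2000 nM to 15000 nM.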

Compound 3, concentration for 50% growth inhibition: 25000 nM
The estimate for compound 3 lay 3.6-fold (0.55 log units) below the measured number; the whole stated range lies below it.
By their numbers in this assay, from the lowest: compounds 1 and 2 (each within the scatter of the next); then compound 3.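

In this assay, this carbon turns out not to accept every group equally: 1H-indol-3-yl gives a 2.5-fold higher number from compound 2 to compound 3 (0.40 log units; beyond the scatter), and measured against the other phenyl group it gives a 2.5-fold higher number from compound 1 to compound 3 (0.40 log units; beyond the scatter). For the compounds shown here, exchanging one substituted phenyl group for another left the value level, so the indole is the first change here to move the number beyond the scatter, and it moves it modestly toward weaker inhibition of growth. Nothing measured here explains this shift.

Going by these compounds, it remains open whether 1-methyl-1H-indol-3-yl at this carbon would read like compound 3 or like compound 2. Also open, on these data alone, is whether any group here, such as a phenyl group carrying an amine, could bring the number lower than the level shared by compound 1 and compound 2.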